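The compounds below may be only part of what the source reports. "The series", "measured", "known", "first", "only" and "open" are said of these compounds alone.

Compound 1 `C=C(Br)C(=O)Nc1ccc(/C=C2\SC(=O)N(Cc3ccc(Cl)cc3)C2=O)cc1` gives 2300 nM in a functional assay on HeLa cells (Homo sapiens) for cytotoxicity, read by cell counting, with a stated time of 4 days; a higher number here means a weaker inhibitor, a lower number a stronger inhibitor.
Compound 2 `C=C(Br)C(=O)Nc1ccc(/C=C2\SC(=O)N(Cc3ccc(C(F)(F)F)cc3)C2=O)cc1` gives 13000 nM in this assay.
Compound 3 `C=C(Br)C(=O)Nc1cccc(/C=C2\SC(=O)N(Cc3ccc(C(F)(F)F)cc3)C2=O)c1` gives 820 nM in this assay.

Compound 1 and compound 2 share one core and differ in a single place: chloro in place of trifluoromethyl on an aromatic carbon. That change produced a 5.7-fold lower number from compound 2 to compound 1 (0.75 log units; beyond the scatter). Compound 3 is built from the same atoms as compound 2, joined differently; the difference between the two cores is not broken down here. Compound 3 has the lowest number of the three, beyond the scatter against both compound 1 and compound 2.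

Compound 4 `C=C(Br)C(=O)Nc1cccc(/C=C2\SC(=O)N(Cc3ccc(Cl)cc3)C2=O)c1` has not yet been tested. It stands to compound 3 exactly as compound 1 stands to compound 2: chloro in place of trifluoromethyl on an aromatic carbon. The place of the change is the same in both pairs, so it counts as the same change on a different core. The expectation for compound 4 in this assay is a step of a 3.3-fold lower number from compound 3 to compound 4 (0.52 log units; beyond the scatter), set somewhat smaller because a 5.7-fold lower number from compound 2 to compound 1 (0.75 log units; beyond the scatter) rests on a single pair on a different core. Compound 4 is estimated at 250 nM, within a range from 80 nM to 800 nM.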

Compound 4, half-maximal inhibitory concentration: 2700 nM
The estimate for compound 4 lay 11-fold (1.03 log units) below the measured number; the whole stated range lies below it.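

On the core of compound 3, putting chloro in place of trifluoromethyl gave a 3.3-fold higher number from compound 3 to compound 4 (0.52 log units; beyond the scatter) in this assay. On the core of compound 1, the same change moved the number the opposite way, so in these compounds its effect did not carry from one core to the other: the same change on two cores in this assay, a 5.7-fold lower number (0.75 log units; beyond the scatter) from compound 2 to compound 1 and a 3.3-fold higher number (0.52 log units; beyond the scatter) from compound 3 to compound 4, 19-fold (1.27 log units) apart, beyond the scatter of two such steps

This shows that the result of the swap was tied to the core carrying it, so a step measured on one core was a poor guide to the other. It does not show why the two cores part, and two pairs give no rule for any further core in the series.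

The compounds shown leave open how other groups would behave in the same place, such as a methoxy group, a nitrile or an amine. They also leave open whether such groups would follow the step seen on one core, the step seen on the other, or neither.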